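Extending an Unsaturated Amide Chain: Three Measured, One Expected

The compounds below may be only part of what the source reports. "The series", "measured", "known", "first", "only" and "open" are said of these compounds alone.

Compound 1 `CC/C=C/C(=O)Nc1cccc(Oc2nc(Nc3cccc(C#N)c3)nc3c2CSCC3)c1` and compound 3 `CC/C=C/C(=O)Nc1cccc(Oc2nc(Nc3ccc(OC)nc3)nc3c2CSCC3)c1` share most of their structure and differ by 6-methoxypyridin-3-yl in place of 3-cyanophenyl on a nitrogen on an aromatic ring. In a functional assay on A549 cells (Homo sapiens) for antiproliferative activity, read by MTT assay, with a stated time of 72 h (on this read-out lower numbers stand for stronger inhibition and higher numbers for weaker inhibition), compound 1 gives 10100 nM, and compound 3 gives 13100 nM, with a 1.3-fold higher number from compound 1 to compound 3 (0.11 log units; within the scatter). Compound 2 `CC(C)/C=C/C(=O)Nc1cccc(Oc2nc(Nc3cccc(C#N)c3)nc3c2CSCC3)c1` carries methyl in place of hydrogen on a saturated chain carbon bound to a double-bonded chain carbon and a saturated chain carbon; in this assay compound 2 gives 35900 nM, giving a 3.6-fold higher number from compound 1 to compound 2 (0.55 log units; beyond the scatter). Compound 4 `CCC/C=C/C(=O)Nc1cccc(Oc2nc(Nc3ccc(OC)nc3)nc3c2CSCC3)c1` is not yet measured and carries methyl in place of hydrogen on a saturated chain carbon, two bonds along the chain from a double-bonded chain carbon. This is the same kind of change as that from compound 1 to compound 2, but the place differs: there the methyl enters on a saturated chain carbon bound to a double-bonded chain carbon and a saturated chain carbon, here on a saturated chain carbon, two bonds along the chain from a double-bonded chain carbon. Because of a 3.6-fold higher number from compound 1 to compound 2 (0.55 log units; beyond the scatter) some weakening is expected for compound 4. The place differs, and the expected step is smaller, namely a 1.4-fold higher number from compound 3 to compound 4 (0.14 log units; within the scatter). Compound 4 is therefore estimated to give 18000 nM, within 8000 nM to 40000 nM.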

Compound 4, half-maximal inhibitory concentration: 10800 nM
Compound 4: the middle estimate sits 1.7-fold (0.22 log units) above what was measured; the range from low to high includes it.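

In this assay, this methyl does not carry over from one core to the other as a fixed step: the same change on two cores in this assay, a 3.6-fold higher number (0.55 log units; beyond the scatter) from compound 1 to compound 2 and a 1.2-fold lower number (0.08 log units; within the scatter) from compound 3 to compound 4, 4.3-fold (0.63 log units) apart, beyond the scatter of two such steps. The new step is a 1.2-fold lower number from compound 3 to compound 4 (0.08 log units; within the scatter), so on the core carrying 6-methoxypyridin-3-yl the added methyl brings no readable difference, unlike the weakening seen on the core carrying 3-cyanophenyl. This does not show the reason: the two steps differ in the core and also in the place of the methyl, and the compounds shown cannot separate these two differences.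

Still open, going by these compounds, is how the methyl would read at each place on the other core. Also open, on these data alone, is how a longer chain than pent-1-en-1-yl, or an amine in its place, would read.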